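The source may report more compounds than this note shows. Statements on the series, on what has been measured and on what is new or still open speak of the compounds shown alone.

Measured so far in an assay on cells with melanin-concentrating hormone receptor 1 (Homo sapiens) as the target, read by radioligand binding; a lower number here means a stronger inhibitor, a higher number a weaker inhibitor:
- compound 1 `Nc1ccc2cccc(OC3CCC3)c2n1`: > 2000 nM, a limit of the assay
- compound 2 `CC(C)=CCOc1cccc2ccc(N)nc12`: > 2000 nM, a limit of the assay
- compound 3 `Nc1ccc2cccc(OCC3CCC3)c2n1`: 432 nM

Within the data shown here, compound 3 holds the only number in this assay; the other two values are limits, both at the limit of > 2000 nM in this assay, at which 2 of the 3 values shown sit. Two measured steps point to compound 3: an at least 4.6-fold lower number from compound 1 to compound 3 (0.66 log units; beyond the scatter) and an at least 4.6-fold lower number from compound 2 to compound 3 (0.66 log units; beyond the scatter). The step that the two limits leave unreadable from compound 1 to compound 2 cannot be read, since both ends are limits.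

Compound 4 `CCCC(C)Oc1cccc2ccc(N)nc12` is to be measured in this assay. Its difference from compound 3 is 1-methylbutyl in place of cyclobutylmethyl on an oxygen on an aromatic ring. The entering 1-methylbutyl matches cyclobutylmethyl in heavy-atom count but opens the ring and, like the cyclobutyl of compound 1, carries its branch at the carbon that sits on the oxygen. Among the measured compounds shown here, the two readable steps, both ending in compound 3 as the sole number, say only that cyclobutylmethyl reads stronger than cyclobutyl and than 3-methylbut-2-en-1-yl; no measured step covers an acyclic saturated branched chain. With compound 1 and compound 2 both at the limit, the expectation leans toward a weaker number than compound 3, though of uncertain size.

Compound 4 is estimated at 1500 nM, within 450 nM to 5000 nM. That corresponds to an expected step of a 3.5-fold higher number from compound 3 to compound 4 (0.54 log units; beyond the scatter), with a real chance that only a limit is reported.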

Compound 4, half-maximal inhibitory concentration: 105 nM
The estimate for compound 4 lay 14-fold (1.15 log units) above the measured number; measured number below the stated range.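

In this assay, the open-chain 1-methylbutyl on an oxygen on an aromatic ring reads stronger than the cyclobutylmethyl of equal heavy-atom count, with a 4.1-fold lower number from compound 3 to compound 4 (0.61 log units; beyond the scatter), so a ring in this group is not required and heavy-atom count alone does not set the number in this pair. The contrast with the two weakest-reading groups is larger, with an at least 19-fold lower number from compound 1 to compound 4 (1.27 log units; beyond the scatter) and an at least 19-fold lower number from compound 2 to compound 4 (1.27 log units; beyond the scatter), which makes compound 4 the strongest of the four and shows that this position responds sharply to the shape of a saturated or unsaturated chain. Both of these larger steps end on a limit at the weak side, so their true size is not fixed and only a minimum can be read: the limit of > 2000 nM in this assay, at which 2 of the 4 values shown sit.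

The order of compound 1 and compound 2 cannot be read, both being limits. From the compounds shown here alone, whether the gain belongs to the branch or to the open chain stays open, as does the reading of an unbranched pentyl chain or a longer chain, or of an amine placed on the chain at this oxygen.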